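This account rests on a few compounds, and the source may have more. Where it says the series, first, only, none or still open, it means among the compounds named here.

Of the compounds shown here, three sharing one core have been tested in a functional assay on DU-145 cells (Homo sapiens) for antiproliferative activity, read by MTT assay, with a stated time of 24 h; on this read-out lower numbers stand for stronger inhibition and higher numbers for weaker inhibition. Compound 1 `COc1ccc(-c2noc(-c3ccccc3)n2)cc1OC1CCCC1` carries a phenyl on an aromatic carbon of the five-membered aromatic ring with two nitrogen and one oxygen; in this assay compound 1 gives only the limit > 1000000 nM. Compound 2 `COc1ccc(-c2noc(-c3cccnc3)n2)cc1OC1CCCC1` carries pyridin-3-yl at that carbon, and in this assay compound 2 also gives only the limit > 1000000 nM. Both of them sit at the limit of > 1000000 nM in this assay, at which 2 of the 3 values shown sit. Going by the values given here, compound 3 `COc1ccc(-c2noc(C3CCNCC3)n2)cc1OC1CCCC1` carries piperidin-4-yl at the same carbon, and in this assay compound 3 gives 57 nM, the only real number among the three. The step of an at least 17000-fold lower number from compound 1 to compound 3 (4.24 log units; beyond the scatter) and the step of an at least 17000-fold lower number from compound 2 to compound 3 (4.24 log units; beyond the scatter) both show that exchanging a six-membered aromatic ring for piperidin-4-yl at this carbon lowers the number at least that far. Compound 4 `COc1ccc(-c2noc(-c3ccc(O)cc3)n2)cc1OC1CCCC1` has not yet been measured; it differs from compound 3 by 4-hydroxyphenyl in place of piperidin-4-yl on an aromatic carbon. The entering group is once more a six-membered aromatic ring of carbon only, as in compound 1, so those two large steps are read in reverse: the number for compound 4 is expected to rise sharply, with a step of a 5300-fold higher number from compound 3 to compound 4 (3.72 log units; beyond the scatter) expected, quite possibly up to the limit. Compound 4 is therefore estimated at 300000 nM, within a range from 5000 nM to 1000000 nM.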

Compound 4, half-maximal inhibitory concentration: 780 nM
The estimate for compound 4 lay 380-fold (2.59 log units) above the measured number, outside the stated range (below it).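

Hydroxy in place of hydrogen on an aromatic carbon gives an at least 1200-fold lower number from compound 1 to compound 4 (3.10 log units; beyond the scatter), and 4-hydroxyphenyl in place of pyridin-3-yl gives an at least 1200-fold lower number from compound 2 to compound 4 (3.10 log units; beyond the scatter), so in this assay a six-membered aromatic ring at this position can go with a real number once it carries that hydroxy. Both of these steps start from a limit and not from a measured number: the limit of > 1000000 nM in this assay, at which 2 of the 4 values shown sit. Piperidin-4-yl is still the better of the two groups with real numbers, as a 14-fold higher number from compound 3 to compound 4 (1.14 log units; beyond the scatter) shows, so a non-aromatic ring gives the lowest number here but is not required for a real number, and these two groups have the same count of hydrogen-bond donors and acceptors.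

The compounds shown cannot tell whether the hydroxy itself matters or whether another group on the phenyl ring would serve as well, as 4-aminophenyl or 4-methoxyphenyl could show. Nor do they show whether a ring is needed at all at this carbon, a question that an open chain such as aminoethyl could address.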